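Replacing the (3,5-dichlorophenyl)carbamoyl group of compound 3

The source may report more compounds than this note shows. Statements on the series, on what has been measured and on what is new or still open speak of the compounds shown alone.

Measured in a functional assay on DU-145 cells (Homo sapiens) for antiproliferative activity, read by sulforhodamine B assay, with a stated time of 3 days; a higher number here means a weaker inhibitor of growth, a lower number a stronger inhibitor of growth:
Compound 1 (`O=C(Nc1ccccn1)c1cccc(Nc2ncc(F)c(Nc3ccc(F)cc3)n2)c1`): (15100 nM)
Compound 2 (`COc1ccc(NC(=O)c2cccc(Nc3ncc(F)c(Nc4ccc(F)cc4)n3)c2)cc1`): (> 10000 nM), which is a limit
Compound 3 (`O=C(Nc1cc(Cl)cc(Cl)c1)c1cccc(Nc2ncc(F)c(Nc3ccc(F)cc3)n2)c1`): (17500 nM)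

Among the measured compounds shown here, compound 3 stands level with compound 1, and the only readable step between measured compounds is (a 1.2-fold higher number from compound 1 to compound 3 (0.06 log units; within the scatter)). Compound 4 (`COCC(=O)Nc1cccc(Nc2ncc(F)c(Nc3ccc(F)cc3)n2)c1`) carries ((methoxymethyl)carbonyl)amino in place of (3,5-dichlorophenyl)carbamoyl on an aromatic carbon. That measured step exchanged one group on the amide nitrogen for another, so it bears on this larger change only loosely. On that step, no change beyond the scatter is expected in this assay. The expected step is (a 1.5-fold lower number from compound 3 to compound 4 (0.16 log units; within the scatter)). Compound 4 is expected at (12000 nM), with an estimated range from (3000 nM) to (40000 nM).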

Compound 4, concentration for 50% growth inhibition: 4460 nM
For compound 4 the middle estimate is 2.7-fold (0.43 log units) above the measured one; the range from low to high includes it.
By their numbers in this assay, from the lowest: compound 4; then compounds 1 and 3 (each within the scatter of the next).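

In this assay the swaps on the amide nitrogen gave no change beyond the scatter, whereas replacing the whole (3,5-dichlorophenyl)carbamoyl group with ((methoxymethyl)carbonyl)amino gives a 3.9-fold lower number from compound 3 to compound 4 (0.59 log units; beyond the scatter) and the same exchange against the pyridin-2-yl amide gives a 3.4-fold lower number from compound 1 to compound 4 (0.53 log units; beyond the scatter). Against compound 2 the result is an at least 2.2-fold lower number from compound 2 to compound 4 (0.35 log units; beyond the scatter), a step that rests on a limit: the limit of > 10000 nM in this assay, at which 1 of the 4 values shown sits. The steps between compound 2 and compounds 1 and 3 cannot be read. The compounds shown leave open whether the direction of the amide or the loss of the ring carries this step, and whether an amine or a longer chain in place of the methoxymethyl group would move the number further.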